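From a dioxolanylmethyl group to a hydroxylated oxane

The source may hold more compounds than are shown below. What is called first, only, known or untested is meant among the compounds shown, and "the series" means these compounds.

Compound 1 `O=C1c2c[n+]([O-])c3ccccc3c2C(=O)c2c1c1ccccc1n2Cc1cn([C@H]2O[C@H](CO)[C@@H](O)[C@H]2O)nn1`: 950 nM
Compound 2 `CC1(C)OCC(Cn2cc(Cn3c4c(c5ccccc53)C(=O)c3c[n+]([O-])c5ccccc5c3C4=O)nn2)O1`: 120 nM
Compound 3 `CC1(C)OC[C@@H](Cn2cc(Cn3c4c(c5ccccc53)C(=O)c3c[n+]([O-])c5ccccc5c3C4=O)nn2)O1`: 2900 nM

In a toxicity assay on L02 cells (Homo sapiens) for cytotoxicity, read by MTT assay, with a stated time of 72 h (on this read-out higher numbers stand for weaker inhibition and lower numbers for stronger inhibition), compound 3 gives the highest of the three numbers. Compound 4 `O=C1c2c[n+]([O-])c3ccccc3c2C(=O)c2c1c1ccccc1n2Cc1cn([C@@H]2O[C@H](CO)[C@@H](O)[C@H](O)[C@H]2O)nn1` carries 3,4,5-trihydroxy-6-(hydroxymethyl)oxan-2-yl in place of (2,2-dimethyl-1,3-dioxolan-4-yl)methyl on an aromatic nitrogen. The closest guide is a 3.1-fold higher number from compound 1 to compound 3 (0.48 log units; beyond the scatter), which installs the departing group in place of 3,4-dihydroxy-5-(hydroxymethyl)oxolan-2-yl. The same exchange runs the other way in a 7.9-fold lower number from compound 1 to compound 2 (0.90 log units; beyond the scatter). Yet a 24-fold higher number from compound 2 to compound 3 (1.38 log units; beyond the scatter) comes with the fact that one of compounds 2 and 3 is drawn with a defined configuration and the other without, at the place where they differ, so the defined compound 3 is followed. Reversing a 3.1-fold higher number from compound 1 to compound 3 (0.48 log units; beyond the scatter), a modest step to a lower number is expected. The expected change is a 2.9-fold lower number from compound 3 to compound 4 (0.46 log units; beyond the scatter). For compound 4 the estimate is 1000 nM, with an expected range of 250 nM to 4000 nM.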

Compound 4, half-maximal inhibitory concentration: 420 nM
For compound 4 the middle estimate is 2.4-fold (0.38 log units) above the measured one, within the range that was stated.
By their numbers in this assay, from the lowest: compound 2; then compound 4; then compound 1; then compound 3.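

In this assay, the 3,4,5-trihydroxy-6-(hydroxymethyl)oxan-2-yl group places compound 4 inside the span of the two dioxolanylmethyl compounds, with a 6.9-fold lower number from compound 3 to compound 4 (0.84 log units; beyond the scatter) but a 3.5-fold higher number from compound 2 to compound 4 (0.54 log units; beyond the scatter). Which of these two steps describes the exchange depends on one feature of the drawings: the fact that one of compounds 2 and 3 is drawn with a defined configuration and the other without, at the place where they differ. Replacing the 3,4-dihydroxy-5-(hydroxymethyl)oxolan-2-yl group at this position gives a modest change, a 2.3-fold lower number from compound 1 to compound 4 (0.35 log units; beyond the scatter). The compounds shown leave open how an amine or a carboxylic acid would read here. They also leave open what the opposite configuration of the dioxolanylmethyl stereocentre would give.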